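Allyl for methyl on the thioether of compound 2

The source may hold more compounds than are shown below. What is called first, only, known or untested is meant among the compounds shown, and "the series" means these compounds.

The compounds share one core. Compound 2 `CSc1nc(N)nc2c1ncn2[C@@H]1C[C@H](O)[C@@H](CO)O1` carries a methylsulfanyl group, compound 3 `CSc1nc(N)nc2c1ncn2[C@H]1C[C@H](O)[C@@H](CO)O1` is the same molecule with one stereocentre at a saturated ring carbon drawn the other way, and compound 1 `Nc1nc(SCc2ccccc2)c2ncn([C@@H]3C[C@H](O)[C@@H](CO)O3)c2n1` carries a benzylsulfanyl group. In a functional assay on L1210 cells (Mus musculus) for inhibition, read by thymidine incorporation (a higher number here means that more compound is needed for the effect, a lower number that less compound is needed), compound 2 gives only a limit, > 100 uM. In this assay compound 3 gives 27 uM. For compound 1 the result in this assay is "not determined" (no result reported). Within the data shown here, the only measured step is an at least 3.7-fold lower number from compound 2 to compound 3 (0.56 log units; beyond the scatter); it rests on the fact that compounds 2 and 3 differ only in the configuration as drawn and on (the limit of > 100 uM in this assay, at which 1 of the 3 values shown sits). Compound 4 `C=CCSc1nc(N)nc2c1ncn2[C@@H]1C[C@H](O)[C@@H](CO)O1` differs from compound 2 by vinyl in place of hydrogen on a saturated chain carbon bound to a sulfur. Among the measured compounds shown here, no measured step touches that change, and compound 1, the nearest comparison for a larger group on the sulfur, has no number. The expected step of an at least 1.2-fold lower number from compound 2 to compound 4 (0.09 log units; that floor lies within the scatter) is therefore set to no change beyond the scatter, with wide bounds and a real chance that only a limit is reported again. Compound 4 is estimated at 80 uM, between 20 uM and 300 uM.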

Compound 4, concentration for half-maximal effect: > 100 uM
Compound 4: a limit, no number; the forecaster's own chance of this, stated with the estimate: 50%; middle value at least 1.2-fold (0.09 log units) away from the limit.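

Among these compounds, no step from compound 2 to compound 4 can be read, because each gives only a limit and no number: the limit of > 100 uM in this assay, at which 2 of the 4 values shown sit. The compounds shown leave open whether allylsulfanyl in place of methylsulfanyl shifts the concentration needed in this assay at all.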